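The source may hold more compounds than are shown below. What is called first, only, known or untested is meant among the compounds shown, and "the series" means these compounds.

In a functional assay on MIA PaCa-2 cells (Homo sapiens) for antiproliferative activity, read by sulforhodamine B assay, with a stated time of 48 h (a higher number here means a weaker inhibitor, a lower number a stronger inhibitor), compound 1 (`COc1cc(OC)c2sc(-c3ccc(N/C=C\C(=O)c4cc(OC)c(OC)c(OC)c4)cc3)nc2c1`) gives 26800 nM, compound 2 (`COc1ccc(C(=O)/C=C\Nc2ccc(-c3nc4cc(OC)c(OC)c(OC)c4s3)cc2)cc1F`) gives 19400 nM and compound 3 (`COc1cc(OC)c2sc(-c3ccc(N/C=C\C(=O)c4ccc(OC)c(F)c4)cc3)nc2c1`) gives 4300 nM. Compound 2 and compound 1 lie within the scatter of each other, and the gap that separates compound 2 from the lowest number is a 4.5-fold lower number from compound 2 to compound 3 (0.65 log units; beyond the scatter). Compound 4 (`COc1cc(C(=O)/C=C\Nc2ccc(-c3nc4cc(OC)c(OC)c(OC)c4s3)cc2)cc(OC)c1OC`) differs from compound 2 in one place: 3,4,5-trimethoxyphenyl in place of 3-fluoro-4-methoxyphenyl on a carbonyl carbon. The same exchange, read in the opposite direction on another core, appears as a 6.2-fold lower number from compound 1 to compound 3 (0.79 log units; beyond the scatter). That step is modest but beyond the scatter, so a modest rise in the number is expected in this assay, meaning weaker inhibition. Among the measured compounds shown here, only this one pair speaks to the exchange, so the estimate assumes that only part of that step carries over to the core of compound 2. The estimated change is a 3.1-fold higher number from compound 2 to compound 4 (0.49 log units; beyond the scatter). For compound 4 the expected value is 60000 nM, with an estimated range of 20000 nM to 150000 nM.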

Compound 4, half-maximal inhibitory concentration: 29100 nM
For compound 4 the middle estimate is 2.1-fold (0.31 log units) above the measured one; low and high end bracket the measured number.
By their numbers in this assay, from the lowest: compound 3; then compounds 2, 1 and 4 (each within the scatter of the next).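

In this assay, 3,4,5-trimethoxyphenyl in place of 3-fluoro-4-methoxyphenyl on a carbonyl carbon gives a 1.5-fold higher number from compound 2 to compound 4 (0.18 log units; within the scatter), so on the core of compound 2 this exchange shows no readable change, and its size depends on the core: the same change on two cores in this assay, a 6.2-fold lower number (0.79 log units; beyond the scatter) from compound 1 to compound 3 and a 1.5-fold lower number (0.18 log units; within the scatter) from compound 4 to compound 2, 4.2-fold (0.62 log units) apart, beyond the scatter of two such steps Methoxy in place of hydrogen on an aromatic carbon gives a 1.1-fold higher number from compound 1 to compound 4 (0.04 log units; within the scatter), so this change also shows no readable effect once 3,4,5-trimethoxyphenyl is present, and it too differs with its setting: the same change on two cores in this assay, a 4.5-fold lower number (0.65 log units; beyond the scatter) from compound 2 to compound 3 and a 1.1-fold lower number (0.04 log units; within the scatter) from compound 4 to compound 1, 4.2-fold (0.62 log units) apart, beyond the scatter of two such steps Each change therefore stands out only in the steps that reach compound 3, and neither can be carried unchanged from one core to the other.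

From the compounds shown here alone, it remains open whether a phenyl ring carrying a dimethylamino group or a carboxylic acid on the carbonyl carbon would follow this dependence. The four compounds also cannot show whether it extends beyond these two cores.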